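From thiophen-3-yl to ethynyl on the shared core

The compounds below may be only part of what the source reports. "The series", "measured", "known", "first", "only" and "open" are said of these compounds alone.

Compound 1 `C#Cc1cn([C@@H]2O[C@H](CO)[C@@H](O)[C@H]2O)c2ncnc(OC)c12`: > 100000 nM
Compound 2 `CN(C)c1ncnc2c1c(-c1ccsc1)cn2[C@@H]1O[C@H](CO)[C@@H](O)[C@H]1O`: > 100000 nM

In an ADME assay on MRC5 cells (Homo sapiens), read by MTT assay, with a stated time of 72 h (on this read-out higher numbers stand for weaker inhibition and lower numbers for stronger inhibition), compound 2 gives > 100000 nM, which is a limit of the assay and not a number. It stands at the limit of > 100000 nM in this assay, at which 2 of the 2 values shown sit. Compound 3 `C#Cc1cn([C@@H]2O[C@H](CO)[C@@H](O)[C@H]2O)c2ncnc(N(C)C)c12` differs from it by one change: ethynyl in place of thiophen-3-yl on an aromatic carbon. Within the data shown here, no measured step shows what this change does. Compound 1 also carries ethynyl, and its reading of > 100000 nM is likewise a limit. On that basis, no step beyond the scatter is expected in this assay. The estimated step is a number no higher from compound 2 to compound 3 (the limit leaves the size open). For compound 3 the expected value is 100000 nM, with an estimated range of 25000 nM to 100000 nM.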

Compound 3, half-maximal inhibitory concentration: 36100 nM
Compound 3: middle estimate off by 2.8-fold (0.44 log units), on the high side; measured number inside the range.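

In this assay, among these compounds, ethynyl in place of thiophen-3-yl on this aromatic carbon brings the first reading that is not a limit, with an at least 2.7-fold lower number from compound 2 to compound 3 (0.44 log units; beyond the scatter). Ethynyl alone does not do this, since compound 1 carries it as well; dimethylamino in place of methoxy on an aromatic carbon gives an at least 2.7-fold lower number from compound 1 to compound 3 (0.44 log units; beyond the scatter), so a measurable value appears here only with both groups together. Both steps start from a limit, and their full size stays open: the limit of > 100000 nM in this assay, at which 2 of the 3 values shown sit.

From the compounds shown here alone, it remains open whether a longer chain such as propynyl at this carbon would lower the number further. Going by these compounds, it is equally open whether a plain amine in place of dimethylamino would keep the value of compound 3.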